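Pyrazolopyrimidine ureas and amides: switch to a pyridyl amide

This account rests on a few compounds, and the source may have more. Where it says the series, first, only, none or still open, it means among the compounds named here.

Of the compounds shown here, two have been measured in an assay on CHO cells for displacement of a labelled ligand from adenosine receptor A1 (Homo sapiens), read by scintillation counting, with a stated time of 120 min, tested at 1 uM; a lower number here means less inhibition, a higher number more inhibition at the concentration tested (going by the name of the read-out). Compound 1 `Cc1nc(NC(=O)NCc2ccccc2)c2nn(-c3ccccc3)cc2n1` gives 26%. Going by the values given here, compound 2 `COc1ccc(C(=O)Nc2nc(C)nc3cn(-c4ccccc4)nc23)cc1` gives 4%, the lowest of the two numbers; the single step from it, a number 22 percentage points lower from compound 1 to compound 2 (beyond the scatter), is a modest drop that lies beyond the scatter and corresponds to 4-methoxyphenyl in place of benzylamino on a carbonyl carbon.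

Compound 3 `Cc1nc(NC(=O)c2cccnc2)c2nn(-c3ccccc3)cc2n1` is not yet measured. It differs from compound 2 as follows: pyridin-3-yl in place of 4-methoxyphenyl on a carbonyl carbon. Among the compounds with values here, no measured step bears directly on this change; the only step known concerns the urea-to-amide switch between compound 1 and compound 2, not an exchange of one aryl group for another on the carbonyl carbon. Compound 3 keeps the amide of compound 2, so the low number of compound 2, 4%, is the nearest reference. The expected step is a number 5 percentage points higher from compound 2 to compound 3 (within the scatter), which is within the scatter. Compound 3 is therefore estimated at 9%, with a range from -5% to 25%.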

Compound 3, a percentage reported as inhibition, at one concentration (the size of the read-out at that concentration, not a potency): 12%
Estimate against measurement, compound 3: 3 percentage points below, and the stated range covers the measured number.
By their numbers in this assay, from the lowest: compounds 2 and 3 (each within the scatter of the next); then compound 1.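

In this assay, an exchange of one aromatic ring for another on the carbonyl carbon of the amide can now be read directly: pyridin-3-yl in place of 4-methoxyphenyl gives a number 8 percentage points higher from compound 2 to compound 3 (within the scatter), so this change, which brings a ring hetero atom and lowers the heavy-atom count from 8 to 6, does not separate the two amides. Set against the urea, the same group gives a number 14 percentage points lower from compound 1 to compound 3 (beyond the scatter), so compound 2 and compound 3 both stand below compound 1 beyond the scatter, and none of the three compounds goes against this pattern, although it rests on a single urea. No available evidence speaks to what lies behind these numbers.

Still open, going by these compounds, is whether a non-aromatic group on the carbonyl carbon, such as cyclohexyl or a longer chain such as n-butyl, would give a number in line with compound 2 and compound 3 or one closer to compound 1. Also open, on these data alone, is whether pyridin-3-yl on a urea, in place of the benzyl group of compound 1, would keep the number of the urea or fall to that of the amides.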